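Propyl in place of acetyl on the shared core

The source may report more compounds than this note shows. Statements on the series, on what has been measured and on what is new or still open speak of the compounds shown alone.

Measured compounds in a functional assay on the whole organism for inhibition, with Nicotiana tabacum as the target; on this read-out higher numbers stand for weaker inhibition and lower numbers for stronger inhibition:
compound 1, `CCc1ccc(Nc2[nH]c(C)nc3nccc2-3)cc1`: 214000000 nM
compound 2, `CC(=O)c1ccc(Nc2[nH]c(C)nc3nccc2-3)cc1`: 646000000 nM

Two compounds share the core and differ only in the group on the aromatic carbon. In this assay compound 2 gives 646000000 nM, the higher of the two numbers, while compound 1 gives 214000000 nM. Among the compounds with values here, the single measured step, a 3.0-fold higher number from compound 1 to compound 2 (0.48 log units; beyond the scatter), is the only guide available.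

Compound 3, `CCCc1ccc(Nc2[nH]c(C)nc3nccc2-3)cc1`, has not yet been measured. It differs from compound 2 in that (propyl in place of acetyl on an aromatic carbon). This change undoes the acetyl and brings in an alkyl chain, so it points in the opposite direction from the step that raised the number on going to compound 2. Within the data shown here, the relevant comparison is therefore that same step, modest in size and beyond the scatter, read backwards; no measured pair involves propyl itself, so the size can only be taken from the ethyl case.

Compound 3 is expected to give about 200000000 nM, with a plausible range from 80000000 nM to 500000000 nM. The expected step is a 3.2-fold lower number from compound 2 to compound 3 (0.51 log units; beyond the scatter), a modest fall in the number toward the level of compound 1.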

Compound 3, half-maximal inhibitory concentration: 105000000 nM
Estimate against measurement, compound 3: 1.9-fold (0.28 log units) above, within the range that was stated.
By their numbers in this assay, from the lowest: compound 3; then compound 1; then compound 2.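

In this assay, the step of a 6.2-fold lower number from compound 2 to compound 3 (0.79 log units; beyond the scatter) shows that replacing acetyl with propyl at this position, para to a large group, lowers the number, as the ethyl compound had suggested in the reverse direction. Within the data shown here, what the earlier compounds could not show is that the alkyl chain itself matters: the step of a 2.0-fold lower number from compound 1 to compound 3 (0.31 log units; beyond the scatter), made by adding methyl on a saturated chain carbon, places compound 3 lowest of the three, so this position distinguishes between two alkyl groups as well as between alkyl and acetyl. Nothing shown here gives a measured reason for either step.

On these data alone, the link between chain length and the number rests on this one pair of alkyl compounds, so it remains open whether a longer chain such as butyl would lower the number further or reverse the fall, and whether a branched group such as isopropyl would behave like propyl. As far as these compounds go, how an amine or a carboxylic acid at this position would compare with the alkyl and acetyl groups also remains unknown.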